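This account rests on a few compounds, and the source may have more. Where it says the series, first, only, none or still open, it means among the compounds named here.

Measured so far in a functional assay on BJAB cells (Homo sapiens) for antiproliferative activity, with a stated time of 4 days; on this read-out higher numbers stand for an effect only at larger amounts of compound and lower numbers for an effect already at smaller amounts:
compound 1 `CCSc1sc(-n2nc(C)c(Cc3ccccc3[N+](=O)[O-])c2C(=O)O)nc1-c1ccc(Cl)c(Cl)c1` — 59000 nM
compound 2 `COC(=O)c1c(Cc2ccccc2[N+](=O)[O-])c(C)nn1-c1nc(-c2ccc(Cl)c(Cl)c2)cs1` — 377000 nM
compound 3 `Cc1cc(-c2c(C)nn(-c3nc(-c4ccc(Cl)c(Cl)c4)c(SC(C)C)s3)c2C(=O)O)cc(C)n1` — 580 nM

Compound 3 gives the lowest number of the three. The nearest value is that of compound 1, which lies well apart from it, beyond the usual scatter; compound 2 stands furthest away, also beyond the scatter. No two of the measured compounds differ in a single place, so no single step can be read off between them.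

Compound 4 `Cc1nn(-c2nc(-c3ccc(Cl)c(Cl)c3)c(SC(C)C)s2)c(C(=O)O)c1-c1ccccc1[N+](=O)[O-]` is the next compound to be measured in this assay. It differs from compound 3 in one place:
2-nitrophenyl in place of 2,6-dimethylpyridin-4-yl on an aromatic carbon

Both compound 1 and compound 2 carry a nitro-bearing phenyl ring, though each also differs from compound 3 elsewhere, so their numbers are only a rough guide. Compound 1 gives 59000 nM in this assay. Compound 2 gives 377000 nM. On that basis, an upward step from compound 3 to compound 4 of a 10-fold higher number from compound 3 to compound 4 (1.01 log units; beyond the scatter) is expected, clearly beyond the scatter. For compound 4 the expected value in this assay is 6000 nM, with a likely range from 1200 nM to 40000 nM.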

Compound 4, half-maximal effective concentration: 4700 nM
Compound 4: the middle estimate sits 1.3-fold (0.11 log units) above what was measured; the measured number falls inside the stated range.
By their numbers in this assay, from the lowest: compound 3; then compound 4; then compound 1; then compound 2.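

Within the data shown here, the first single-place step falls on the aromatic carbon of the five-membered ring with 2 nitrogen, next to the ring atoms that bear the carboxy and methyl groups: in this assay, 2-nitrophenyl in place of 2,6-dimethylpyridin-4-yl gives an 8.1-fold higher number from compound 3 to compound 4 (0.91 log units; beyond the scatter). Among these compounds, the read-out therefore responds to what is attached at this carbon, even though a six-membered aromatic ring stands there in both compound 3 and compound 4, which the earlier compounds, with no single-place pair among them, could not show. Nothing at hand accounts for the size or direction of this step.

This single swap changes several features at once: the ring nitrogen and the methyl groups leave, and the nitro group enters, so the compounds shown do not assign the step to any one of them. Also open, from the compounds shown here alone, is how an unsubstituted phenyl, a pyridin-4-yl without methyl groups or a 2-aminophenyl would read at this carbon with the rest of compound 3 unchanged.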